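The source may hold more compounds than are shown below. What is called first, only, known or untested is meant among the compounds shown, and "the series" means these compounds.

Measured so far in a functional assay on MCF7 cells (Homo sapiens) for inhibition, read by MTT assay, with a stated time of 72 h; a lower number here means a stronger inhibitor, a higher number a weaker inhibitor:

compound 1 `CC(C)c1ccc(-c2nc(SCc3cn(CC(=O)NC(=O)Nc4ccccn4)nn3)nc(Nc3ccc(Cl)cc3)c2C#N)cc1` — in this assay compound 1 gives only a limit of the assay, > 64000 nM.
compound 2 `CC(C)c1ccc(-c2nc(SCc3cn(CC(=O)NC(=O)Nc4ccccn4)nn3)nc(Nc3ccccc3F)c2C#N)cc1` — in this assay compound 2 gives only a limit, > 64000 nM.
compound 3 `Cc1cccc(Nc2nc(SCc3cn(CC(=O)NC(=O)Nc4ccccn4)nn3)nc(-c3ccc(C(C)C)cc3)c2C#N)c1` — in this assay compound 3 gives only a limit, > 64000 nM.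

Compound 1 therefore stands at a limit and not at a number in this assay, and the two further values shown are limits of the same kind. The steps among the measured compounds, a step that the two limits leave unreadable from compound 1 to compound 2, a step that the two limits leave unreadable from compound 1 to compound 3 and a step that the two limits leave unreadable from compound 2 to compound 3, cannot be read in size, since all three values sit at the same limit (the limit of > 64000 nM in this assay, at which 3 of the 3 values shown sit).

Compound 4 `COc1ccccc1Nc1nc(SCc2cn(CC(=O)NC(=O)Nc3ccccn3)nn2)nc(-c2ccc(C(C)C)cc2)c1C#N` is not yet measured in this assay. The change from compound 1 to compound 4 is 2-methoxyphenyl in place of 4-chlorophenyl on a nitrogen on an aromatic ring. It is of the same kind as the measured steps, a changed aryl group on the same nitrogen on an aromatic ring. Those steps give no readable size, so no direction and no size beyond the scatter can be expected from them; the expectation rests on the shared limit (the limit of > 64000 nM in this assay, at which 3 of the 3 values shown sit), which suggests compound 4 will likewise be reported only as a limit. Compound 4 is estimated at 100000 nM in this assay, within 40000 nM to 300000 nM. The step from compound 1 implied by this estimate is a step that the limit leaves unreadable from compound 1 to compound 4, expected to be unreadable against a limit.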

Compound 4, half-maximal inhibitory concentration: 19300 nM
Beside the measured number, compound 4's estimate is 5.2-fold (0.71 log units) above it, outside the stated range (below it).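

In this assay, the aryl group on the nitrogen on an aromatic ring now produces readable steps, with 2-methoxyphenyl giving an at least 3.3-fold lower number from compound 1 to compound 4 (0.52 log units; beyond the scatter) and an at least 3.3-fold lower number from compound 3 to compound 4 (0.52 log units; beyond the scatter). The narrowest of the three changes, methoxy in place of fluoro on an aromatic carbon, gives an at least 3.3-fold lower number from compound 2 to compound 4 (0.52 log units; beyond the scatter), so the change in this one substituent is enough to bring a value into the measurable range of the assay. The steps among compound 1, compound 2 and compound 3 cannot be read, and compound 4 is the only compound shown with a number rather than a limit of the assay: the limit of > 64000 nM in this assay, at which 3 of the 4 values shown sit.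

The compounds shown leave open whether the methoxy group is specifically what matters on this aromatic carbon, and an amine or a longer ether chain in the same place would put that to the test. They also leave open how far the series can move from the 19300 nM of compound 4, and whether the same change would carry over with another group in place of the rest of the molecule.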